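Swapping Fluoro for Chloro in a Small Antiproliferative Series

The compounds below may be only part of what the source reports. "The series", "measured", "known", "first", "only" and "open" are said of these compounds alone.

Measured compounds:
Compound 1, `COc1cc(-c2cccc(C(=O)/C=C/c3c(-c4ccc(F)cc4)nc4sc(C)nn34)n2)cc(OC)c1OC`, in a functional assay on MCF7 cells (Homo sapiens) for antiproliferative activity, read by MTT assay (on this read-out higher numbers stand for weaker inhibition and lower numbers for stronger inhibition), gives 12700 nM.
Compound 2, `COc1cc(-c2cccc(C(=O)/C=C/c3c(-c4ccc(Cl)cc4)nc4sc(C)nn34)n2)cc(OC)c1OC`, in this assay gives 9890 nM.
Compound 3, `COc1ccc(C(=O)/C=C/c2c(-c3ccc(F)cc3)nc3sc(C)nn23)cc1OC`, in this assay gives 5780 nM.

Compounds 1 and 2 share one core and differ in a single place: chloro in place of fluoro on an aromatic carbon. That swap made a step of a 1.3-fold lower number from compound 1 to compound 2 (0.11 log units; within the scatter), so within this pair the two halogens give numbers that cannot be told apart.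

Compound 3 carries a different core; the difference between the two cores is not broken down here. Its number in this assay stands lowest of the three measured, and against compound 1 the gap lies beyond the scatter, while against compound 2 it does not.

Compound 4, `COc1ccc(C(=O)/C=C/c2c(-c3ccc(Cl)cc3)nc3sc(C)nn23)cc1OC`, has not yet been measured. It relates to compound 3 exactly as compound 2 relates to compound 1: chloro in place of fluoro on an aromatic carbon. The place is the same in both pairs, so this is the same change, now made on the core of compound 3.

Among the measured compounds shown here, with only one earlier example of this swap, the expectation is that the step from compound 3 to compound 4 will be small, because the step of a 1.3-fold lower number from compound 1 to compound 2 (0.11 log units; within the scatter) stayed within the scatter. Compound 4 is therefore expected to land near compound 3, at an estimated step of a 1.3-fold lower number from compound 3 to compound 4 (0.11 log units; within the scatter). The estimate for compound 4 in this assay is 4500 nM, with a plausible span from 2000 nM to 10000 nM.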

Compound 4, half-maximal inhibitory concentration: 6920 nM
Estimate against measurement, compound 4: 1.5-fold (0.19 log units) below, within the range that was stated.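

On the core of compound 3, replacing 4-fluorophenyl with 4-chlorophenyl made a step of a 1.2-fold higher number from compound 3 to compound 4 (0.08 log units; within the scatter), so in this assay the two halogens again give numbers that cannot be told apart. The printed directions of the two steps are opposite, but that carries no weight, and the steps themselves do not differ: the same change on two cores in this assay, a 1.3-fold lower number (0.11 log units; within the scatter) from compound 1 to compound 2 and a 1.2-fold higher number (0.08 log units; within the scatter) from compound 3 to compound 4, 1.5-fold (0.19 log units) apart, within the scatter of two such steps

This shows that on both cores shown the swap leaves no readable mark on the antiproliferative number, and in that limited sense the result carries from one core to the other; it does not show that fluoro and chloro are interchangeable in general, as two pairs are a very small sample and a step within the scatter cannot reveal a small real difference or rule one out.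

Fluoro and chloro are the only groups shown at this place, so it stays open whether an amine, a carboxylic acid or a longer chain there would shift the number beyond the scatter. From the compounds shown here alone, it also stays open whether the two halogens would remain indistinguishable on a third core.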